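Bis(trifluoromethyl)benzenesulfonamide amines: methylated versus free amine

The source may report more compounds than this note shows. Statements on the series, on what has been measured and on what is new or still open speak of the compounds shown alone.

Three members of this series have numbers in a functional assay on PANC-1 cells (Homo sapiens) for inhibition, read by MTT assay, with a stated time of 72 h; on this read-out lower numbers stand for stronger inhibition of growth and higher numbers for weaker inhibition of growth. Compound 1 `O=S(=O)(NCCCNCc1ccc(Cl)c(C(F)(F)F)c1)c1cc(C(F)(F)F)cc(C(F)(F)F)c1` gives 10000 nM in this assay. Compound 3 `CC(C)(C)c1ccc(CNCCNS(=O)(=O)c2cc(C(F)(F)F)cc(C(F)(F)F)c2)cc1` gives 13000 nM in this assay. Within the data shown here, for compound 2 `CN(CCCNS(=O)(=O)c1cc(C(F)(F)F)cc(C(F)(F)F)c1)Cc1ccccc1` this assay reports only a limit, > 50000 nM, so compound 2 stands at the weak end of what has been measured and its true value is unknown; it is the one compound sitting at the limit of > 50000 nM in this assay, at which 1 of the 3 values shown sits. Among the measured compounds shown here, no pair of measured compounds differs in a single place, so no measured step is available.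

Compound 4 `COc1ccccc1CNCCCNS(=O)(=O)c1cc(C(F)(F)F)cc(C(F)(F)F)c1` is not yet measured. It differs from compound 2 by (2-methoxybenzyl)amino in place of benzyl(methyl)amino on a saturated chain carbon, three bonds along the chain from a sulfonamide nitrogen. Compound 1 with 10000 nM and compound 3 with 13000 nM both carry the same kind of chain amine as compound 4, which is the only ground for an expectation. The step of an at least 3.3-fold lower number from compound 2 to compound 4 (0.52 log units; beyond the scatter) is therefore expected to run toward stronger inhibition of growth, beyond the usual scatter, though its size cannot be fixed against a limit. Compound 4 is expected to give about 15000 nM in this assay, within a range of 5000 nM to 45000 nM.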

Compound 4, concentration for 50% growth inhibition: 12000 nM
Estimate against measurement, compound 4: 1.3-fold (0.10 log units) above, and the stated range covers the measured number.
By their numbers in this assay, from the lowest: compounds 1, 4 and 3 (each within the scatter of the next). At a limit, above all of these: compound 2.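

Compound 2 stands only at a limit of the assay: the limit of > 50000 nM in this assay, at which 1 of the 4 values shown sits.

Even so, (2-methoxybenzyl)amino in place of benzyl(methyl)amino on this saturated chain carbon gives an at least 4.1-fold lower number from compound 2 to compound 4 (0.61 log units; beyond the scatter), the first measured step at this place; it lies beyond the scatter, and its full size stays unfixed. With 2-methoxyphenyl in place of 4-chloro-3-(trifluoromethyl)phenyl, the series gives a 1.2-fold higher number from compound 1 to compound 4 (0.08 log units; within the scatter), within the scatter, so these two aryl groups are not told apart in this assay.

The step at the amine carries two changes at once, loss of the methyl and entry of the methoxy, and the compounds shown do not separate them; plain benzylamino would be the group to read that against. Also open, on these data alone, is how an amide or a carboxylic acid would read in place of the chain amine.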